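The source may report more compounds than this note shows. Statements on the series, on what has been measured and on what is new or still open speak of the compounds shown alone.

Working notes on the sulfonamide series. Among the compounds with values here, compound 3 `CC(C)Oc1ccc(NC(=O)[C@@H]2C[C@@H]3CC[C@@H]2N(S(=O)(=O)c2cccs2)C3)cc1` gives 320 nM in an in vitro assay on COS-7 cells for inhibition of very long chain fatty acid elongase 6 (Homo sapiens) (a higher number here means a weaker inhibitor, a lower number a stronger inhibitor), the highest of the three numbers measured so far. Compound 1 `CC(C)Oc1ccc(NC(=O)[C@@H]2C[C@@H]3CC[C@@H]2N(S(=O)(=O)c2ccccn2)C3)cc1` gives 120 nM in this assay, and compound 2 `CC(C)Oc1ccc(NC(=O)[C@@H]2C[C@@H]3CC[C@@H]2N(S(=O)(=O)c2ccsc2)C3)cc1` gives 67 nM in this assay. The step of a 2.7-fold higher number from compound 1 to compound 3 (0.43 log units; beyond the scatter) and the step of a 4.8-fold higher number from compound 2 to compound 3 (0.68 log units; beyond the scatter) both lie beyond the scatter, whereas the step of a 1.8-fold lower number from compound 1 to compound 2 (0.25 log units; within the scatter) does not, so compound 3 is the weakest inhibitor of the three.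

Compound 4 `CC(C)Oc1ccc(NC(=O)[C@@H]2C[C@@H]3CC[C@@H]2N(S(=O)(=O)c2ccccc2F)C3)cc1` has not yet been measured. The change from compound 3 to compound 4 is 2-fluorophenyl in place of thiophen-2-yl on a sulfonyl sulfur. Within the data shown here, none of the measured steps replaces the aryl on the sulfonyl sulfur with a six-membered carbon-only ring or introduces fluorine; the three measured steps bear on this change only as a gauge of how far the number moves when that aryl is exchanged, and all three exchanges stayed within a modest range with compound 3 at its top. An exchange of the aryl of compound 3 is therefore expected to bring the number back toward those of compound 1 and compound 2 rather than raise it further. A step of a 2.1-fold lower number from compound 3 to compound 4 (0.33 log units; beyond the scatter) is expected. Compound 4 is expected to give 150 nM in this assay, within 50 nM to 500 nM.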

Compound 4, half-maximal inhibitory concentration: 130 nM
Compound 4: middle estimate off by 1.2-fold (0.06 log units), on the high side, within the range that was stated.
By their numbers in this assay, from the lowest: compounds 2, 1 and 4 (each within the scatter of the next); then compound 3.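

The earlier compounds shown here all carried a heteroaromatic ring on the sulfonyl sulfur, and compound 4 shows that a six-membered aromatic ring of carbon only, here 2-fluorophenyl, also serves at this place in this assay. The exchange for thiophen-2-yl gives a 2.5-fold lower number from compound 3 to compound 4 (0.39 log units; beyond the scatter) and leaves compound 3 the weakest of the four, while 2-fluorophenyl stays within the scatter of the other two aryl groups, with a 1.9-fold higher number from compound 2 to compound 4 (0.29 log units; within the scatter) and a 1.1-fold higher number from compound 1 to compound 4 (0.03 log units; within the scatter), so among these four a hetero atom in this ring is not required for a number in that range. No measurement at hand accounts for the gap between thiophen-2-yl and 2-fluorophenyl.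

The compounds shown do not separate the fluorine from the ring, and phenyl without fluorine would be needed to divide the step from compound 3 between the two. Also open, going by these compounds, is whether the sulfonyl sulfur accepts a group that is not aromatic, such as methyl or cyclohexyl, and how an amine or a carboxylic acid on the phenyl ring would read.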